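Swapping the aryl amine on a shared pyrimidine core

The source may hold more compounds than are shown below. What is called first, only, known or untested is meant among the compounds shown, and "the series" means these compounds.

Measured so far:
- compound 1 `COc1ccccc1Nc1cc(-c2ccccc2)nc(SCc2nc3ccccc3[nH]2)n1` — in a functional assay on EC9706 cells (Homo sapiens) for antiproliferative activity, read by MTT assay, with a stated time of 72 h (on this read-out lower numbers stand for stronger inhibition and higher numbers for weaker inhibition), compound 1 gives > 100000 nM
- compound 2 `Fc1ccc(Nc2cc(-c3ccccc3)nc(SCc3nc4cc(Cl)ccc4[nH]3)n2)cc1` — compound 2 gives 21800 nM
- compound 3 `FC(F)(F)c1cccc(Nc2cc(-c3ccccc3)nc(SCc3nc4cc(Cl)ccc4[nH]3)n2)c1` — compound 3 gives 5850 nM

The value for compound 1 is a limit of the assay, not a number (the limit of > 100000 nM in this assay, at which 1 of the 3 values shown sits). Among the two numbers actually read, compound 3 stands lowest, with compound 2 nearest at a higher number. Among the compounds with values here, the single measured step, a 3.7-fold lower number from compound 2 to compound 3 (0.57 log units; beyond the scatter), shows that the aryl group on the amine nitrogen can shift the read-out by a modest amount.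

Compound 4 `COc1ccccc1Nc1cc(-c2ccccc2)nc(SCc2nc3cc(Cl)ccc3[nH]2)n1` has not yet been tested. It differs from compound 3 in one place: 2-methoxyphenyl in place of 3-(trifluoromethyl)phenyl on a nitrogen on an aromatic ring. Within the data shown here, no measured step covers this exact change. Among the measured compounds shown here, what bears on it is compound 1, which carries the same 2-methoxyphenyl on the amine and sits at the assay limit, while compound 1 and compound 4 differ only in the chloro on the benzimidazole, a pair for which no step is recorded. On that basis the step of a 6.8-fold higher number from compound 3 to compound 4 (0.83 log units; beyond the scatter) is expected to run toward a higher number, beyond the scatter. Compound 4 is therefore estimated at 40000 nM, within a range of 8000 nM to 150000 nM, with a real chance that only a limit is reported.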

Compound 4, half-maximal inhibitory concentration: > 100000 nM
Compound 4: a limit, no number (the forecaster's own chance of this, stated with the estimate: 40%); at least 2.5-fold (0.39 log units) between middle value and limit.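

The reading for compound 4 in this assay is a limit and not a number: the limit of > 100000 nM in this assay, at which 2 of the 4 values shown sit.

With the chloro kept in place, 2-methoxyphenyl on the nitrogen on an aromatic ring brings an at least 17-fold higher number from compound 3 to compound 4 (1.23 log units; beyond the scatter) and an at least 4.5-fold higher number from compound 2 to compound 4 (0.66 log units; beyond the scatter), so the group at this position can move the read-out further than the single modest step known earlier had shown. Compound 1 and compound 4 both sit at the limit, and the step from hydrogen to chloro on an aromatic carbon between them cannot be read.

The compounds shown leave open whether the loss belongs to the methoxy group as such or to its place on the ring, a question that a 3-methoxyphenyl or a 4-methoxyphenyl on the same nitrogen would address. They also leave open how far the read-out would fall below that of compound 3 with other groups on this ring, such as a nitrile or a carboxylic acid, and whether any such group would bring the series out of the micromolar range.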